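This account rests on a few compounds, and the source may have more. Where it says the series, first, only, none or still open, it means among the compounds named here.

Measured so far:
compound 1 `[O-][S+](CCC(F)=C(F)F)c1nc2ccccc2s1`: 7000 nM
compound 2 `FC(F)(Cl)C(F)(Cl)CCSc1nc2ccc(Cl)cc2s1`: > 120000 nM

Compound 2 is recorded in a functional assay on SH-SY5Y cells (Homo sapiens) for cytotoxicity, read by MTT assay, with a stated time of 48 h (on this read-out lower numbers stand for stronger inhibition and higher numbers for weaker inhibition), only as a limit, > 120000 nM, not as a number. Compound 2 therefore sits at the limit of > 120000 nM in this assay, at which 1 of the 2 values shown sits. Compound 1, which carries the sulfoxide and a different chain, gives 7000 nM in this assay, a number rather than a limit.

Compound 3 `FC(F)(Cl)C(F)(Cl)CCSc1nc2ccccc2s1` is yet to be measured in this assay. It differs from compound 2 by hydrogen in place of chloro on an aromatic carbon. Among the compounds with values here, no step between two measured compounds is available, so the size of this change cannot be read from the series itself; the expectation is a step no larger than the scatter, in either direction. Compound 3 is accordingly estimated at 100000 nM, between 25000 nM and 400000 nM, with a real chance that only a limit is reported again. This estimate means an at least 1.2-fold lower number from compound 2 to compound 3 (0.07 log units; that floor lies within the scatter).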

Compound 3, half-maximal inhibitory concentration: > 120000 nM
Compound 3: no number, only a limit (the forecaster's own chance of this, stated with the estimate: 55%); middle value at least 1.2-fold (0.07 log units) away from the limit.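

Within the data shown here, compound 2 and compound 3 are both recorded only as limits in this assay, and no step between them can be read. The compounds shown leave open whether hydrogen in place of chloro on an aromatic carbon changes the read-out at all, and by how much.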